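This account rests on a few compounds, and the source may have more. Where it says the series, first, only, none or still open, it means among the compounds named here.

Compound 1 `Clc1ccc(OCc2nc3c(OCCC4CCNCC4)cccc3n2CCCC2CCCNC2)cc1`: in an assay on isolated protein for binding affinity to Neuropeptide Y receptor type 1 (Homo sapiens) (on this read-out lower numbers stand for stronger inhibition and higher numbers for weaker inhibition), compound 1 gives 7 nM.
Compound 2 `Clc1ccc(OCc2nc3ccccc3n2CCN2CCCCC2)cc1`: in this assay compound 2 gives no number, only the limit > 100000 nM.

For the measured compounds named here, compound 1 therefore stands alone as the only actual number in this assay; the other entry is not a measured value but a limit of the assay, namely (the limit of > 100000 nM in this assay, at which 1 of the 2 values shown sits), so no step between measured compounds can be read off here, and nothing beyond the two values themselves can be said about the pair.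

The compound to be measured next is compound 3 `Clc1ccc(OCc2nc3c(OCCCN4CCCCC4)cccc3n2CCCC2CCCNC2)cc1`. It keeps the whole of compound 1 apart from one change: (piperidin-1-yl)methyl in place of piperidin-4-yl on a saturated chain carbon, two bonds along the chain from an oxygen on an aromatic ring. The chain between the aromatic oxygen and the ring nitrogen thus stays of comparable length, while the nitrogen moves from inside the ring to the chain end.

Going by the values given here, with no measured step of this kind to lean on, the expectation is a small step from compound 1 to compound 3, estimated at a 2.1-fold higher number from compound 1 to compound 3 (0.33 log units; beyond the scatter), at most a little beyond the usual scatter. Compound 3 is accordingly expected to give about 15 nM in this assay, within a range from 3 nM to 80 nM.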

Compound 3, inhibition constant: 1.7 nM
The estimate for compound 3 lay 8.8-fold (0.95 log units) above the measured number; the measured number lies below the stated range.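

Swapping the 2-(piperidin-4-yl)ethoxy chain of compound 1 for the 3-(piperidin-1-yl)propoxy chain of compound 3 gives, in this assay, a 4.1-fold lower number from compound 1 to compound 3 (0.61 log units; beyond the scatter), so this position accepts a ring attached through its nitrogen at the chain end as well as one attached through a ring carbon, and the number improves modestly rather than being lost. The group that leaves carries a hydrogen-bond donor and the group that enters carries none, so the hydrogen on the ring nitrogen of compound 1 is not required for a low number in this assay. Nothing measured among these compounds explains why the number falls with this change.

This single step alters the chain and the attachment of the ring together, so the compounds shown cannot separate the contribution of each, and a 2-(piperidin-1-yl)ethoxy chain would be needed to begin pulling them apart. Also open, going by these compounds, is how far the position tolerates other ends to the chain, such as a morpholin-4-yl ring, a dimethylamino group or a carboxylic acid, or a longer chain such as 4-(piperidin-1-yl)butoxy.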